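Trading a Phenyl for Fluoro on the Shared Core

A few compounds are considered here, and "the series" means these few. Any claim that something is new, unique, unknown or untested is made for them only; others in the source may bear on it.

Of the compounds shown here, two have so far been tested in an assay on isolated protein for displacement of a labelled ligand from prostaglandin D2 receptor 2 (Homo sapiens); a lower number here means a stronger inhibitor, a higher number a weaker inhibitor. Compound 1, `COc1cccc(S(=O)(=O)c2c(C)n(CC(=O)O)c3ccc(C)cc23)c1`, gives 71 nM in this assay . Compound 2, `Cc1c(Sc2ccc(Cl)cc2)c2cc(-c3ccccc3)ccc2n1CC(=O)O`, gives 3.5 nM in this assay , the lowest of the two numbers, with compound 1 standing well beyond the scatter above it.

Compound 3, `Cc1c(Sc2ccc(Cl)cc2)c2cc(F)ccc2n1CC(=O)O`, has not yet been measured. It differs from compound 2 in one place: fluoro in place of phenyl on an aromatic carbon. A six-atom phenyl ring leaves and a single fluorine atom enters on the same aromatic carbon of the shared core. Going by the values given here, no pair of measured compounds differing in one place is available to calibrate this kind of change, so its size can only be guessed. The expected step in this assay is a moderate weakening, from compound 2 to compound 3 a 3.4-fold higher number from compound 2 to compound 3 (0.54 log units; beyond the scatter), beyond the scatter but not dramatic. Compound 3 is therefore estimated at 12 nM in this assay , with a likely range from 3 nM to 45 nM.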

Compound 3, half-maximal inhibitory concentration in the prostaglandin D2 receptor 2 assay: 1.6 nM
The estimate for compound 3 lay 7.5-fold (0.88 log units) above the measured number, outside the stated range (below it).
By their numbers in the prostaglandin D2 receptor 2 assay, from the lowest: compound 3; then compound 2; then compound 1.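

Replacing phenyl with fluoro on this aromatic carbon gives a 2.2-fold lower number from compound 2 to compound 3 (0.34 log units; beyond the scatter), so binding does not depend on a six-membered aromatic ring at this position, and a single fluorine atom serves at least as well. Stronger binding here also comes without high lipophilicity, as a physicochemical assay for lipophilicity, at pH 7.4 (a higher number here means a more lipophilic compound, a lower number a more polar compound), shows for this pair: the measured distribution coefficient of compound 2, 3.7, and of compound 3, 1.8, a number 1.90 log units lower (beyond the scatter). In the physicochemical assay compound 2 gives 3.7 and compound 3 gives 1.8. This is a single pair on one core, so it describes this change and no general rule.

The compounds shown leave open whether fluoro itself contributes or whether removing phenyl is enough, a question that plain hydrogen on the same carbon would address. A methoxy group or an amine there would show how much other groups at this position change both numbers.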